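The source may hold more compounds than are shown below. What is called first, only, known or untested is meant among the compounds shown, and "the series" means these compounds.

Compound 1 `N#Cc1cnc(NCc2cnccc2C(F)(F)F)cc1NC[C@H]1C[C@@H](O)C1` gives 300 nM in an assay on isolated protein for inhibition of protein kinase C theta type (Homo sapiens), read by TR-FRET, with a stated time of 2 h; on this read-out lower numbers stand for stronger inhibition and higher numbers for weaker inhibition.
Compound 2 `CO[C@H]1CC[C@@H](Nc2cc(NCc3cnccc3C(F)(F)F)ncc2C#N)CC1` gives 58 nM in this assay.
Compound 3 `CO[C@H]1CC[C@@H](CNc2cc(NCc3cnccc3C(F)(F)F)ncc2C#N)CC1` gives 70 nM in this assay.

Of these three numbers compound 2 has the lowest; compound 3 sits within the scatter of it, and only compound 1 lies clearly apart, as a 5.2-fold lower number from compound 1 to compound 2 (0.71 log units; beyond the scatter) shows. Compound 4 `N#Cc1cnc(NCc2cnccc2C(F)(F)F)cc1NCC1CCOCC1` has not yet been measured. It differs from compound 2 in one place: (oxan-4-yl)methyl in place of 4-methoxycyclohexyl on a nitrogen on an aromatic ring. Two things happen here at once. A single carbon is inserted between the ring and the nitrogen, and the ring itself is exchanged. The insertion alone has a precedent, a 1.2-fold higher number from compound 2 to compound 3 (0.08 log units; within the scatter), which stayed within the scatter. Among the measured compounds shown here, the ring exchange has no direct precedent; the only ring changes on record, a 5.2-fold lower number from compound 1 to compound 2 (0.71 log units; beyond the scatter) and a 4.3-fold lower number from compound 1 to compound 3 (0.63 log units; beyond the scatter), swapped a smaller ring bearing a hydroxyl for the methoxycyclohexyl ring and gave modest gains. Removing that same ring in favour of an oxanyl ring could therefore cost something, but the size is uncertain. A modest weakening is expected, a 2.2-fold higher number from compound 2 to compound 4 (0.35 log units; beyond the scatter), in this assay. Compound 4 is estimated at 130 nM, with a plausible range from 50 nM to 350 nM.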

Compound 4, half-maximal inhibitory concentration: 400 nM
Compound 4: the middle estimate sits 3.1-fold (0.49 log units) below what was measured; measured number outside the range, above it.
By their numbers in this assay, from the lowest: compounds 2 and 3 (each within the scatter of the next); then compounds 1 and 4 (each within the scatter of the next).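

With the chain carbon on the nitrogen held constant, the ring alone matters in this assay: oxan-4-yl in place of 4-methoxycyclohexyl gives a 5.7-fold higher number from compound 3 to compound 4 (0.76 log units; beyond the scatter) and so the two rings are not interchangeable at this place, even though each group counts one hydrogen-bond acceptor and no donor. Exchanging the ring and adding the carbon together gives a 6.9-fold higher number from compound 2 to compound 4 (0.84 log units; beyond the scatter) while the added carbon alone gives a 1.2-fold higher number from compound 2 to compound 3 (0.08 log units; within the scatter) and so the loss follows the ring and not the extra carbon. The comparison with the smaller ring gives a 1.3-fold higher number from compound 1 to compound 4 (0.12 log units; within the scatter) and so oxan-4-yl and 3-hydroxycyclobutyl cannot be told apart on that saturated chain carbon, where of these three groups only 4-methoxycyclohexyl gives a clearly lower number.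

Still open, on these data alone, is which part of 4-methoxycyclohexyl carries the gain: a plain cyclohexyl, a 4-hydroxycyclohexyl or an oxan-4-yl placed directly on the nitrogen would separate the outer methoxy group from the carbon ring that bears it. Nothing available explains why this ring exchange changes the number.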